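Nitrile to tetrazole at the end of the alkoxy chain

This account rests on a few compounds, and the source may have more. Where it says the series, first, only, none or still open, it means among the compounds named here.

Three compounds of the series have numbers in an assay on isolated protein for inhibition of leukotriene B4 receptor 1 (Homo sapiens), tested at 10 uM; a higher number here means more inhibition at the concentration tested (going by the name of the read-out), a lower number less inhibition. Compound 1 `CC(=O)c1cc(CC2CO2)c(OCCCCC#N)cc1O` gives 62%. Compound 2 `COCc1cc(C(C)=O)c(O)cc1OCCCCCCC#N` gives 47%. Compound 3 `CCc1cc(C(C)=O)c(O)cc1OCCCCCCC(C)(C)C#N` gives 65%. The number for compound 3 is the highest of the three, but the number for compound 1 lies within the scatter of it, so no order between compound 3 and compound 1 can be read; only compound 2 lies beyond the scatter, below compound 3. Among the compounds with values here, no step between two measured compounds that differ in a single place is available, so the effect of any one change on the shared core remains unknown from the data themselves.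

Compound 4 `CCc1cc(C(C)=O)c(O)cc1OCCCCCCc1nnn[nH]1` is the next compound to be measured. It differs from compound 3 as follows: 1H-tetrazol-5-yl in place of 1-cyano-1-methylethyl on a saturated chain carbon, six bonds along the chain from an oxygen on an aromatic ring. Nothing in the measured set shows what a group of this kind does at this place in this assay. With the number for compound 3 already high, the expected step of a number 5 percentage points higher from compound 3 to compound 4 (within the scatter) in this assay is small and upward, not clearly beyond the scatter. Compound 4 is therefore estimated to give 70%, with a range from 45% to 90%.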

Compound 4, a percentage reported as inhibition, at one concentration (the size of the read-out at that concentration, not a potency): 91%
Estimate against measurement, compound 4: 21 percentage points below; measured number above the stated range.
By their numbers in this assay, from the lowest: compound 2; then compounds 1 and 3 (each within the scatter of the next); then compound 4.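

In this assay, 1H-tetrazol-5-yl in place of 1-cyano-1-methylethyl on a saturated chain carbon, six bonds along the chain from an oxygen on an aromatic ring, gives a number 26 percentage points higher from compound 3 to compound 4 (beyond the scatter). Within the data shown here, this is the first step that changes a single place, and it shows that the read-out responds to the group at the end of the chain, which the earlier compounds, differing in more than one place, could not show. The heavy-atom count stays the same across the change, whereas the nitrile and its two methyl groups leave and a five-membered aromatic ring with 4 hetero atoms enters, so the step goes with the kind of group and not with its count of heavy atoms.

Open, from the compounds shown here alone, is whether a carboxylic acid or a primary amide at the chain end would match 1H-tetrazol-5-yl, whether a shorter or longer chain would keep the step, and whether the same replacement would hold with the other groups carried by compound 1 and compound 2. No measurement at hand bears on what lies behind the step.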